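The source may hold more compounds than are shown below. What is called first, only, known or untested is meant among the compounds shown, and "the series" means these compounds.

Measured so far:
Compound 1 `O=C(CSc1nc(Nc2ccccc2)c2ccccc2n1)Nc1ccccc1Cl`; in a functional assay on PC-3 cells (Homo sapiens) for inhibition, read by MTT assay, with a stated time of 72 h (a higher number here means a weaker inhibitor, a lower number a stronger inhibitor), compound 1 gives 14600 nM.
Compound 2 `C=CC(=O)Nc1cccc(NC(=O)CSc2nc(Nc3ccccc3)c3ccccc3n2)c1`; in this assay compound 2 gives 8740 nM.

Compound 2 stands lowest of the two numbers, its nearest neighbour being compound 1; the step of a 1.7-fold lower number from compound 1 to compound 2 (0.22 log units; within the scatter) lies within the scatter, so the two values are not separable.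

Compound 3 `O=C(CSc1nc(Nc2ccccc2)c2ccccc2n1)Nc1ccc(Cl)cc1` has not yet been measured. It differs from compound 2 by 4-chlorophenyl in place of 3-((vinylcarbonyl)amino)phenyl on an amide-type nitrogen. Within the data shown here, the one measured step that bears on this change is a 1.7-fold lower number from compound 1 to compound 2 (0.22 log units; within the scatter), which exchanged a chlorophenyl for the vinylcarbonylamino-bearing phenyl on the same nitrogen without moving beyond the scatter. Compound 1, which carries 2-chlorophenyl at that place, gives 14600 nM in this assay.

Compound 3 is therefore expected to show a step of a 1.4-fold higher number from compound 2 to compound 3 (0.14 log units; within the scatter), not beyond the scatter. Compound 3 is estimated at 12000 nM, within a range of 4000 nM to 40000 nM.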

Compound 3, half-maximal inhibitory concentration: 12900 nM
Beside the measured number, compound 3's estimate is 1.1-fold (0.03 log units) below it; the range from low to high includes it.
By their numbers in this assay, from the lowest: compounds 2, 3 and 1 (each within the scatter of the next).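

With 4-chlorophenyl in place of 2-chlorophenyl on the amide-type nitrogen, this assay shows a 1.1-fold lower number from compound 1 to compound 3 (0.05 log units; within the scatter) and so does not separate these two chlorophenyl compounds. With 4-chlorophenyl in place of 3-((vinylcarbonyl)amino)phenyl, the same read-out shows a 1.5-fold higher number from compound 2 to compound 3 (0.17 log units; within the scatter) and so, for a second chlorophenyl partner, the loss of this larger group with its two double bonds outside aromatic rings also stays within the scatter. No measurement at hand explains any of these values. The compounds shown leave open how a benzyl group or a longer alkyl chain would read on the amide-type nitrogen. They also leave open whether a propanoylamino group on the phenyl would read like the 3-((vinylcarbonyl)amino)phenyl group of compound 2.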